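This account rests on a few compounds, and the source may have more. Where it says the series, first, only, none or still open, it means among the compounds named here.

Compound 1 `N#Cc1c(N)sc(C(=O)Nc2ccc(Cl)cc2)c1-c1ccccc1` and compound 3 `N#Cc1c(N)sc(C(=O)Nc2ccccc2)c1-c1ccccc1` share one core and differ in a single spot. In a functional assay on MKN-45 cells (Homo sapiens) for inhibition, read by MTT assay (a higher number here means a weaker inhibitor, a lower number a stronger inhibitor), compound 1 gives 420 nM. Compound 3 gives 7090 nM in this assay. The change between them is hydrogen in place of chloro on an aromatic carbon, and it made a step of a 17-fold higher number from compound 1 to compound 3 (1.23 log units; beyond the scatter).

Compound 2 `CCOC(=O)c1c(NC(=O)CC#N)sc(C(=O)Nc2ccc(Cl)cc2)c1-c1ccccc1` is built on a second core; how that core differs from the core of compound 1 is not broken down here. In this assay compound 2 gives 390 nM, which sits close to compound 1 and far from compound 3.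

Compound 4 `CCOC(=O)c1c(NC(=O)CC#N)sc(C(=O)Nc2ccccc2)c1-c1ccccc1` is the not yet measured partner of compound 2. The change from compound 2 to compound 4 is hydrogen in place of chloro on an aromatic carbon; this is the same change as the one from compound 1 to compound 3, made at the same kind of place, and among these compounds it occurs twice in all. Because the first instance gave a 17-fold higher number from compound 1 to compound 3 (1.23 log units; beyond the scatter), a step of about a 17-fold higher number from compound 2 to compound 4 (1.22 log units; beyond the scatter) is expected here as well. On that basis compound 4 is estimated at 6500 nM, likely between 2500 nM and 17000 nM, in this assay.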

Compound 4, half-maximal inhibitory concentration: 590 nM
Beside the measured number, compound 4's estimate is 11-fold (1.04 log units) above it, outside the stated range (below it).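

Taking the chloro off does not give a fixed step in this series. In this assay, the swap of 4-chlorophenyl to phenyl gives a 17-fold higher number from compound 1 to compound 3 (1.23 log units; beyond the scatter) on the first core, but a 1.5-fold higher number from compound 2 to compound 4 (0.18 log units; within the scatter) on the second, so the large step does not carry over from one core to the other. The comparison of the two steps bears this out: the same change on two cores in this assay, a 17-fold higher number (1.23 log units; beyond the scatter) from compound 1 to compound 3 and a 1.5-fold higher number (0.18 log units; within the scatter) from compound 2 to compound 4, 11-fold (1.05 log units) apart, beyond the scatter of two such steps

This shows that, for these two pairs, the effect of the swap depends on the core it is made on, so a step measured on one core is a poor guide to the other. It does not show which part of the core is responsible or why, and two pairs cannot say how the swap would behave on any further core.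

The compounds shown carry only chloro or hydrogen at this place on the ring, so a fluoro, methyl or methoxy group there remains open. Also open, going by these compounds, is which of the differences between the two cores sets the size of the step.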